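Swapping methyl for chloro in compound 3

A few compounds are considered here, and "the series" means these few. Any claim that something is new, unique, unknown or untested is made for them only; others in the source may bear on it.

Measured in a functional assay on MCF7 cells (Homo sapiens) for cytotoxicity, read by ELISA, with a stated time of 4 days; a lower number here means a stronger inhibitor, a higher number a weaker inhibitor:
- compound 1 `Cc1ccsc1-c1cc(-c2ccoc2)cc(-c2ccco2)n1`: 18300 nM
- compound 2 `Clc1ccc(-c2cc(-c3ccoc3)cc(-c3ccco3)n2)s1`: 4740 nM
- compound 3 `Cc1cccc(-c2cc(-c3ccoc3)cc(-c3ccc(Cl)s3)n2)c1`: 3990 nM

Compound 3, at 3990 nM, sits well under compound 1 and cannot be told apart from compound 2 within the scatter. The next compound, compound 4 `Clc1cccc(-c2cc(-c3ccoc3)cc(-c3ccc(Cl)s3)n2)c1`, alters one group: chloro in place of methyl on an aromatic carbon. Here chloro takes the place of methyl on an aromatic carbon, so 3-methylphenyl becomes 3-chlorophenyl.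

Going by the values given here, two measured steps bear on this change. The step of a 3.9-fold lower number from compound 1 to compound 2 (0.59 log units; beyond the scatter) is the only one in which a methyl-bearing group gives way to a chloro-bearing group. It was modest, but it concerns a different group, 3-methylthiophen-2-yl becoming 5-chlorothiophen-2-yl, so it carries over only loosely. The step of a 1.2-fold lower number from compound 2 to compound 3 (0.07 log units; within the scatter) shows that 3-methylphenyl in place of furan-2-yl left the number within the scatter. Among the compounds with values here, no measured pair swaps methyl for chloro on this ring.

A small shift in this assay is therefore expected, leaning toward a lower number and possibly lost in the scatter. The expected change is a 1.3-fold lower number from compound 3 to compound 4 (0.12 log units; within the scatter). For compound 4 the estimated value is 3000 nM, with an expected range of 1300 nM to 7000 nM.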

Compound 4, half-maximal inhibitory concentration: 2920 nM
Estimate against measurement, compound 4: 1.0-fold (0.01 log units) above; the measured number falls inside the stated range.
By their numbers in this assay, from the lowest: compounds 4, 3 and 2 (each within the scatter of the next); then compound 1.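

In this assay, going by these compounds alone, the change from 3-methylphenyl to 3-chlorophenyl gives a 1.4-fold lower number from compound 3 to compound 4 (0.14 log units; within the scatter) and so provides the first direct reading of chloro in place of methyl on this ring, where the two compounds cannot be told apart. Compound 4 also cannot be told apart from the furan-2-yl compound, with a 1.6-fold lower number from compound 2 to compound 4 (0.21 log units; within the scatter) as the printed step, so furan-2-yl, 3-methylphenyl and 3-chlorophenyl in compounds 2, 3 and 4 all give numbers within the scatter of one another. Nothing measured here offers a reason for this lack of separation.

Still open, on these data alone, is whether an amine, a carboxylic acid or a longer chain in place of chloro on this ring would move the number beyond the scatter. It is also unknown whether the same swap of methyl for chloro would stay this quiet with a group other than 5-chlorothiophen-2-yl elsewhere on the shared core, or with a different core altogether.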